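A Carbonyl Swap Near the Limit of the Assay

The source may hold more compounds than are shown below. What is called first, only, known or untested is meant among the compounds shown, and "the series" means these compounds.

In a functional assay on OVCAR-3 cells (Homo sapiens) for antiproliferative activity, read by MTT assay, with a stated time of 24 h (on this read-out higher numbers stand for weaker inhibition and lower numbers for stronger inhibition), compound 1 (`Cc1cccc(NNC(=O)c2ccc(NS(=O)(=O)c3cnc(O)nc3O)cc2)c1`) gives > 20000 nM as its reading, which is a limit of the assay and not a number. Compound 2 (`Cc1ccccc1NNC(=O)c1ccccc1NS(=O)(=O)c1cnc(O)nc1O`) gives > 20000 nM as its reading, again a limit. Compound 3 (`O=C(NNc1ccccc1Cl)c1ccccc1NS(=O)(=O)c1cnc(O)nc1O`) gives an actual number of 14100 nM as its reading. The results crowd against the limit of > 20000 nM in this assay, at which 2 of the 3 values shown sit, with little room left to read differences. Compound 4 (`Cc1ccccc1C(=O)NNC(=O)c1ccc(NS(=O)(=O)c2cnc(O)nc2O)cc1`) carries (2-methylphenyl)carbonyl in place of 3-methylphenyl on an amine nitrogen when set against compound 1. Among the measured compounds shown here, the only measured step, an at least 1.4-fold lower number from compound 2 to compound 3 (0.15 log units; that floor lies within the scatter) for chloro in place of methyl on an aromatic carbon, is a different change, so no step beyond the scatter is expected in this assay here. The expected step is a step that the limit leaves unreadable from compound 1 to compound 4 by this estimate. Compound 4 is expected at 22000 nM with an estimated range of 10000 nM to 50000 nM in all.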

Compound 4, half-maximal inhibitory concentration: > 20000 nM
Compound 4 ended at the assay's limit; the forecaster's own chance of this, stated with the estimate: 65%; the middle value lies beyond the limit too.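

No new step can be read from compound 1 to compound 4, since both readings are limits and not numbers: the limit of > 20000 nM in this assay, at which 3 of the 4 values shown sit. The compounds shown leave open whether (2-methylphenyl)carbonyl in place of 3-methylphenyl on an amine nitrogen changes the reading in this assay.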